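The source may hold more compounds than are shown below. What is called first, only, known or untested is meant among the compounds shown, and "the series" means these compounds.

Measured so far in a functional assay on PC-9 cells (Homo sapiens) for inhibition, read by MTT assay, with a stated time of 48 h, tested at 10 uM; on this read-out lower numbers stand for less inhibition and higher numbers for more inhibition at the one concentration tested (going by the name of the read-out):
Compound 1 `COc1cc(NC(=O)Nc2cc(Nc3ccc(C(C)(C)C)cc3)ncn2)cc(OC)c1` gives 74.1%.
Compound 2 `COc1ccc(F)cc1Nc1cc(NC(=O)Nc2c(Cl)cccc2Cl)ncn1` gives 85.5%.
Compound 3 `COc1cc(NC(=O)Nc2cc(Nc3ccc(C)c(F)c3)ncn2)cc(OC)c1` gives 77.5%.

Compound 3 sits second highest of the three numbers; its nearest neighbour is compound 1, and compound 2 stands furthest, yet both gaps lie within the scatter, so no order among them can be read. Compound 4 `COc1cc(NC(=O)Nc2cc(Nc3cc(F)ccc3OC)ncn2)cc(OC)c1` differs from compound 3 in one place: 5-fluoro-2-methoxyphenyl in place of 3-fluoro-4-methylphenyl on a nitrogen on an aromatic ring. Going by the values given here, the only comparable change, the swap of the same group on the same nitrogen, gave a number 3.4 percentage points higher from compound 1 to compound 3 (within the scatter), a change too small to count. Among the compounds with values here, nothing among the measured compounds separates these groups beyond the scatter, so for compound 4 the expected step in this assay is a number 0.5 percentage points higher from compound 3 to compound 4 (within the scatter), with no direction beyond the scatter. Compound 4 is estimated at 78%, between 63% and 90%.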

Compound 4, a percentage reported as inhibition, at one concentration (the size of the read-out at that concentration, not a potency): 59.5%
Beside the measured number, compound 4's estimate is 18.5 percentage points above it; measured number below the stated range.
By their numbers in this assay, from the lowest: compound 4; then compounds 1, 3 and 2 (each within the scatter of the next, the first and the last beyond it).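

In this assay the swap to 5-fluoro-2-methoxyphenyl on a nitrogen on an aromatic ring gives a number 18 percentage points lower from compound 3 to compound 4 (beyond the scatter) and also a number 14.6 percentage points lower from compound 1 to compound 4 (beyond the scatter) so this place can move the number beyond the scatter, which the earlier swap there did not show. The other place counts too: 3,5-dimethoxyphenyl in place of 2,6-dichlorophenyl on an amide-type nitrogen gives a number 26 percentage points lower from compound 2 to compound 4 (beyond the scatter) with the 5-fluoro-2-methoxyphenyl group kept. Nothing measured here gives a reason for these drops.

Going by these compounds, whether the methoxy or the fluorine of the entering group goes with the drop stays open. So does how a phenyl carrying an amine or a carboxylic acid would read at this nitrogen.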